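This account rests on a few compounds, and the source may have more. Where it says the series, first, only, none or still open, it means among the compounds named here.

Within the data shown here, in a functional assay on MDA-MB-231 cells (Homo sapiens) for inhibition, read by CCK-8 assay and cell counting, with a stated time of 2 days (a lower number here means a stronger inhibitor, a higher number a weaker inhibitor), only two compounds sharing one core have numbers so far. Compound 1 (`O=C(/C=C/c1ccco1)c1ccc(OCC2CO2)cc1`), which carries furan-2-yl, gives 47100 nM and compound 2 (`O=C(/C=C/c1cccs1)c1ccc(OCC2CO2)cc1`), which carries thiophen-2-yl, gives 28300 nM as its reading. Among the measured compounds shown here, the measured step between them is a 1.7-fold lower number from compound 1 to compound 2 (0.22 log units; within the scatter) and nothing more, so compound 2 stands level with its only neighbour on these numbers. Compound 3 (`O=C(/C=C/c1ccoc1)c1ccc(OCC2CO2)cc1`) has furan-3-yl in place of thiophen-2-yl on a double-bonded chain carbon bound to a double-bonded chain carbon, a swap counted as (furan-3-yl in place of thiophen-2-yl on a double-bonded chain carbon bound to a double-bonded chain carbon). For the measured compounds named here, the one measured step is the only guide here, as compound 1 with furan-2-yl at 47100 nM stays within the scatter of compound 2. Going by the values given here, no measured compound carries furan-3-yl, however, and that gap widens the range. In this assay the expected change is a 1.3-fold higher number from compound 2 to compound 3 (0.13 log units; within the scatter) and so no step beyond the scatter. Compound 3 is expected at 38000 nM with an estimated range from 17000 nM to 85000 nM for its reading.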

Compound 3, half-maximal inhibitory concentration: 26200 nM
Compound 3: the middle estimate sits 1.5-fold (0.16 log units) above what was measured; the range from low to high includes it.
By their numbers in this assay, from the lowest: compounds 3, 2 and 1 (each within the scatter of the next).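

In this assay a third ring now sits on the double-bonded chain carbon bound to a double-bonded chain carbon, and furan-3-yl in place of thiophen-2-yl gives a 1.1-fold lower number from compound 2 to compound 3 (0.03 log units; within the scatter), so swapping the sulfur-containing ring for this oxygen-containing one leaves no readable change. The two furans can now also be compared, and furan-3-yl in place of furan-2-yl gives a 1.8-fold lower number from compound 1 to compound 3 (0.25 log units; within the scatter), so among these three compounds neither the hetero atom nor the difference between the 2-yl and 3-yl forms of the furan separates the readings. No outside measurement is available to explain why these readings stay so close.

As far as these compounds go, all three groups are five-membered aromatic rings with one hetero atom, so it remains open whether a different group at this position, such as a phenyl ring, a dimethylamino group or a carboxylic acid, would move the number beyond the scatter. From the compounds shown here alone, it also remains open whether a change elsewhere on the shared core would have a larger effect than these ring swaps.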